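Hexyl to 3,5-difluorophenyl on the shared core

This account rests on a few compounds, and the source may have more. Where it says the series, first, only, none or still open, it means among the compounds named here.

Compound 1 `O=c1cc(Cn2cc(CCCO)nn2)c2ccc(O)cc2o1` and compound 2 `CCCCCCc1cn(Cc2cc(=O)oc3cc(O)ccc23)nn1` share one core and differ on the side chain. In a functional assay on HepG2 cells (Homo sapiens) for inhibition, read by MTT assay, with a stated time of 72 h (a higher number here means a weaker inhibitor, a lower number a stronger inhibitor), compound 1 gives > 100000 nM, which is a limit of the assay (the limit of > 100000 nM in this assay, at which 1 of the 2 values shown sits). In this assay, for the measured compounds named here, compound 2 gives 61600 nM, the only number so far among the values shown. Going by the values given here, the single measured comparison is an at least 1.6-fold lower number from compound 1 to compound 2 (0.21 log units; that floor lies within the scatter), a change on a saturated chain carbon whose floor lies within the scatter. Compound 3 `O=c1cc(Cn2cc(-c3cc(F)cc(F)c3)nn2)c2ccc(O)cc2o1` differs from compound 2 by 3,5-difluorophenyl in place of hexyl on an aromatic carbon. The measured step from compound 1 to compound 2 concerns a different place and a different kind of group and offers little guidance for a change on an aromatic carbon. No shift beyond the scatter is therefore expected in this assay from compound 2 to compound 3. The expected step is a 1.5-fold lower number from compound 2 to compound 3 (0.19 log units; within the scatter). Compound 3 is estimated at 40000 nM, with a range from 12000 nM to 130000 nM.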

Compound 3, half-maximal inhibitory concentration: 38900 nM
Estimate against measurement, compound 3: 1.0-fold (0.01 log units) above; the measured number falls inside the stated range.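

On the aromatic carbon of the five-membered ring, a ring-bearing group and a saturated chain are not separated: in this assay the change from hexyl to 3,5-difluorophenyl gives a 1.6-fold lower number from compound 2 to compound 3 (0.20 log units; within the scatter) and so shows no shift that can be read. Against 3-hydroxypropyl, the same 3,5-difluorophenyl group gives an at least 2.5-fold lower number from compound 1 to compound 3 (0.41 log units; beyond the scatter) and this is the first step shown that clears the scatter. That step is only a floor, set by the limit for compound 1: the limit of > 100000 nM in this assay, at which 1 of the 3 values shown sits.

Going by these compounds, whether a phenyl ring without fluorine would stand level with compound 3 remains open, so no role can be assigned to the two fluorines. Also open, on these data alone, is whether an amine, a carboxylic acid or a chain longer than hexyl at this carbon would move the number beyond the scatter from compound 2.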